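The source may hold more compounds than are shown below. What is called first, only, known or untested is meant among the compounds shown, and "the series" means these compounds.

Measured compounds:
- compound 1, `CC1CCN(C2CCN(S(=O)(=O)c3cccc(C(F)(F)F)c3)CC2)CC1`: > 5000 nM, a limit of the assay
- compound 2, `Cc1cc(C)c(S(=O)(=O)N2CCN(C3CN4CCC3CC4)CC2)c(C)c1`: > 5000 nM, a limit of the assay
- compound 3, `CC1CCN(C2CCN(S(=O)(=O)c3ccc(Br)cc3OC(F)(F)F)CC2)CC1`: > 5000 nM, a limit of the assay

These three compounds were tested in an ADME assay on HCT-116 cells (Homo sapiens) for cytotoxicity, read by CellTiter-Glo, with a stated time of 72 h; a lower number here means a stronger inhibitor, a higher number a weaker inhibitor. For compound 1 the result is only a limit, > 5000 nM, not a number. Among the compounds with values here, the same holds for the other two compounds, so that the limit of > 5000 nM in this assay, at which 3 of the 3 values shown sit: every value shown stops at the same edge, and no compound can be placed above or below another.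

Compound 4, `Cc1cccc(S(=O)(=O)N2CCC(N3CCC(C)CC3)CC2)c1`, shares the core of compound 1 and differs from it in one place: methyl in place of trifluoromethyl on an aromatic carbon. Within the data shown here, no step between measured compounds is available to say how such a change shifts this assay. Given that compound 1 sits at the limit, compound 4 is expected to remain there as well, so the step that the limit leaves unreadable from compound 1 to compound 4 is expected to be none beyond the scatter. For compound 4 the estimate is 10000 nM, expected to fall between 5000 nM and 30000 nM, most likely reported again only as a limit.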

Compound 4, half-maximal inhibitory concentration: > 5000 nM
Compound 4 ended at the assay's limit; the forecaster's own chance of this, stated with the estimate: 85%; the middle value lies beyond the limit too.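

Compound 1 and compound 4 both stop at a limit rather than a number, so the change from trifluoromethyl to methyl gives no step that can be read: the limit of > 5000 nM in this assay, at which 4 of the 4 values shown sit.

The compounds shown leave open what structural change, if any, would give a measurable value in this assay.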